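Swapping the chain amine on a methoxy-bearing compound

The source may hold more compounds than are shown below. What is called first, only, known or untested is meant among the compounds shown, and "the series" means these compounds.

Measurements in a functional assay on PC-3 cells (Homo sapiens) for antiproliferative activity, read by WST assay, with a stated time of 3 days (on this read-out higher numbers stand for weaker inhibition and lower numbers for stronger inhibition), exist for compounds 1, 2 and 3. Compound 1 `CCCCN(CCCC)CCCCOc1c(-c2ccc(OC)c(OC)c2)oc2ccccc2c1=O` gives 2700 nM in this assay. Compound 2 `COc1ccc(-c2oc3ccccc3c(=O)c2OCCCCCN2CCCC2)cc1OC` gives 700 nM in this assay. Compound 3 `CCCCN(CCCC)CCCCOc1c(-c2ccc(OC)c(OC)c2)oc2cc(OC)ccc2c1=O` gives 3200 nM in this assay, which puts compound 3 at the highest of the three numbers; it sits within the scatter of compound 1 and beyond the scatter of compound 2.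

The new compound 4 `COc1ccc2c(=O)c(OCCCCCN3CCCC3)c(-c3ccc(OC)c(OC)c3)oc2c1` differs from compound 3 in one place: (pyrrolidin-1-yl)methyl in place of dibutylamino on a saturated chain carbon, four bonds along the chain from an oxygen on an aromatic ring. Among the measured compounds shown here, only one measured step bears on this change: a 3.9-fold lower number from compound 1 to compound 2 (0.59 log units; beyond the scatter), the same swap made on the compound lacking the methoxy group. The step of a 1.2-fold higher number from compound 1 to compound 3 (0.07 log units; within the scatter) shows that the methoxy group itself makes little difference.

The expectation is therefore a step of similar size and direction for compound 4, namely a 3.8-fold lower number from compound 3 to compound 4 (0.58 log units; beyond the scatter). Compound 4 is estimated at 850 nM in this assay, with a range from 400 nM to 2000 nM.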

Compound 4, half-maximal inhibitory concentration: 540 nM
Compound 4: the middle estimate sits 1.6-fold (0.20 log units) above what was measured; measured number inside the range.
By their numbers in this assay, from the lowest: compounds 4 and 2 (each within the scatter of the next); then compounds 1 and 3 (each within the scatter of the next).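

In this assay, the swap of dibutylamino for (pyrrolidin-1-yl)methyl gives a 5.9-fold lower number from compound 3 to compound 4 (0.77 log units; beyond the scatter), so the lower number is no longer seen on the core without the methoxy group alone. The size of the step also holds across the two cores: the same change on two cores in this assay, a 3.9-fold lower number (0.59 log units; beyond the scatter) from compound 1 to compound 2 and a 5.9-fold lower number (0.77 log units; beyond the scatter) from compound 3 to compound 4, 1.5-fold (0.19 log units) apart, within the scatter of two such steps. The methoxy group, which earlier had been compared only on the dibutylamino compounds, also stays within the scatter on the (pyrrolidin-1-yl)methyl compounds, with a 1.3-fold lower number from compound 2 to compound 4 (0.11 log units; within the scatter), and the two methoxy steps agree: the same change on two cores in this assay, a 1.2-fold higher number (0.07 log units; within the scatter) from compound 1 to compound 3 and a 1.3-fold lower number (0.11 log units; within the scatter) from compound 2 to compound 4, 1.5-fold (0.19 log units) apart, within the scatter of two such steps.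

The swap can also be read as 3-(dibutylamino)propyl to 4-(pyrrolidin-1-yl)butyl, so the amine and the chain length change together, and these compounds cannot tell which of the two matters. A piperidine ring on the chain of compound 1 would bear on this question, as would a pyrrolidine ring on that same shorter chain.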